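Transferring an indole nitrogen substituent swap to a second core

The source may hold more compounds than are shown below. What is called first, only, known or untested is meant among the compounds shown, and "the series" means these compounds.

Measured compounds:
Compound 1 `C#CCNC1CCc2c(OCCCCN3CCN(c4cccc5c4ccn5Cc4cccc(Cl)c4)CC3)cccc21`: 113 nM
Compound 2 `C#CCNC1CCc2c(OCCCCN3CCN(c4cccc5c4ccn5S(=O)(=O)c4ccccc4)CC3)cccc21`: 50 nM
Compound 3 `C#CCN(C)Cc1ccc(OCCCCCN2CCN(c3cccc4c3ccn4Cc3cccc(Cl)c3)CC2)cc1`: 140 nM

The study follows three measured compounds and one still untested in an assay on HEK293 cells for displacement of a labelled ligand from 5-hydroxytryptamine receptor 6 (Homo sapiens), read by scintillation counting, with a stated time of 1 h; on this read-out lower numbers stand for stronger inhibition and higher numbers for weaker inhibition. Compound 1 and compound 2 share one core and differ only in phenylsulfonyl in place of 3-chlorobenzyl on an aromatic nitrogen. That change gave a 2.3-fold lower number from compound 1 to compound 2 (0.35 log units; beyond the scatter). Compound 3 carries a different core; how it differs from the core of compound 1 is not broken down here. In this assay compound 3 gives 140 nM, which sits within the scatter of compound 1 and beyond it relative to compound 2.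

Compound 4 `C#CCN(C)Cc1ccc(OCCCCCN2CCN(c3cccc4c3ccn4S(=O)(=O)c3ccccc3)CC2)cc1` is built from compound 3 by phenylsulfonyl in place of 3-chlorobenzyl on an aromatic nitrogen. The place is the same word for word as for the earlier pair, so this is the same change made a second time, now on the core of compound 3. Its effect has been seen only once, so the expectation rests on a single step. Within the data shown here, compound 4 is expected to show a 2.3-fold lower number from compound 3 to compound 4 (0.37 log units; beyond the scatter), a step of about the size seen between compound 1 and compound 2, because a 2.3-fold lower number from compound 1 to compound 2 (0.35 log units; beyond the scatter) is the only guide available. Compound 4 is therefore estimated at 60 nM, with a likely range from 25 nM to 150 nM.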

Compound 4, inhibition constant: 38 nM
Estimate against measurement, compound 4: 1.6-fold (0.20 log units) above; measured number inside the range.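

In this assay, phenylsulfonyl in place of 3-chlorobenzyl on the aromatic nitrogen gave a 3.7-fold lower number from compound 3 to compound 4 (0.57 log units; beyond the scatter), and the change lowered the number on the second core as it had on the first. The two steps agree in direction and, within what repeated measurement allows, in size, and in this series the change carried from one core to the other: the same change on two cores in this assay, a 2.3-fold lower number (0.35 log units; beyond the scatter) from compound 1 to compound 2 and a 3.7-fold lower number (0.57 log units; beyond the scatter) from compound 3 to compound 4, 1.6-fold (0.21 log units) apart, within the scatter of two such steps. This rests on just two pairs of compounds in a single read-out; it does not show that the step would hold on any further core, nor does it explain why the two cores respond alike.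

The compounds shown leave open whether an unsubstituted benzyl group or a phenylsulfonyl group with a chlorine on its ring would give a similar step on either core. Also open is how a methanesulfonyl or benzoyl group on the same nitrogen would compare with the two groups shown here.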